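Ring swap at the aromatic position: compound 3 to compound 4

The compounds below may be only part of what the source reports. "The series", "measured", "known", "first", "only" and "open" are said of these compounds alone.

Going by the values given here, the series so far holds three compounds. Compound 1 `COc1ccc(S(=O)(=O)N2CCc3cccc(-c4ccc(F)nc4)c32)cc1` gives 109 nM in a functional assay on HT-29 cells (Homo sapiens) for inhibition, with a stated time of 72 h; a lower number here means a stronger inhibitor, a higher number a weaker inhibitor. Compound 2 `COc1ccc(-c2cccc3c2N(S(=O)(=O)c2ccc(OC)cc2)CC3)cc1` gives 277 nM in this assay, and compound 3 `COc1ccc(S(=O)(=O)N2CCc3cccc(-c4cccs4)c32)cc1` gives 200 nM. Compound 3 therefore stands second highest of the three numbers; the gap to its nearest neighbour is a 1.4-fold lower number from compound 2 to compound 3 (0.14 log units; within the scatter), and the gap to the furthest is a 1.8-fold higher number from compound 1 to compound 3 (0.26 log units; within the scatter), both within the scatter. Between the two six-membered rings the step is a 2.5-fold higher number from compound 1 to compound 2 (0.41 log units; beyond the scatter).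

Compound 4 `COc1ccc(S(=O)(=O)N2CCc3cccc(-c4cccc(F)c4)c32)cc1` is not yet measured. It differs from compound 3 in one place: 3-fluorophenyl in place of thiophen-2-yl on an aromatic carbon. Among the compounds with values here, the steps that bear on this change are the two that exchange a six-membered ring for thiophen-2-yl, a 1.8-fold higher number from compound 1 to compound 3 (0.26 log units; within the scatter) and a 1.4-fold lower number from compound 2 to compound 3 (0.14 log units; within the scatter), neither beyond the scatter. Returning to a six-membered ring is thus expected to move the number little, and if anything slightly down, as a 1.3-fold lower number from compound 3 to compound 4 (0.12 log units; within the scatter). For compound 4 the estimated value in this assay is 150 nM, with a range from 70 nM to 350 nM.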

Compound 4, half-maximal inhibitory concentration: 119 nM
Compound 4: the middle estimate sits 1.3-fold (0.10 log units) above what was measured; measured number inside the range.
By their numbers in this assay, from the lowest: compounds 1, 4, 3 and 2 (each within the scatter of the next, the first and the last beyond it).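

In this assay, the 3-fluorophenyl group of compound 4 gives a result that cannot be told apart from that of the 6-fluoropyridin-3-yl group, with a 1.1-fold higher number from compound 1 to compound 4 (0.04 log units; within the scatter), so at this aromatic carbon a six-membered aromatic ring of carbon only matches that ring in this assay. The change from thiophen-2-yl stays small, with a 1.7-fold lower number from compound 3 to compound 4 (0.23 log units; within the scatter), while the change from 4-methoxyphenyl gives a 2.3-fold lower number from compound 2 to compound 4 (0.37 log units; beyond the scatter), so compound 2 now stands beyond the scatter of both fluorinated compounds, though compound 3 remains within the scatter of all three others. No supporting measurement accounts for these differences.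

Going by these compounds, all four groups at this position are single aromatic rings, so the effect of an aminomethyl group, a carboxylic acid or a morpholine ring there remains open. Unsubstituted phenyl also remains open, leaving the contribution of fluorine undefined.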